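Para Substitution on the Aryl Ring in a Cytotoxicity Series

This account rests on a few compounds, and the source may have more. Where it says the series, first, only, none or still open, it means among the compounds named here.

Measured compounds:
compound 1 `O=Cc1c(-c2ccc(Br)cc2)nc2sc(Cc3ccc(Cl)cc3)nn12`: 4200 nM
compound 2 `O=Cc1c(-c2ccccc2)nc2sc(Cc3ccc(Cl)cc3)nn12`: 45000 nM

For the measured compounds named here, in a functional assay on HeLa cells (Homo sapiens) for cytotoxicity, with a stated time of 72 h (on this read-out lower numbers stand for stronger inhibition and higher numbers for weaker inhibition), compound 2 gives the higher of the two numbers, with compound 1 the only neighbour at a lower value; the step of an 11-fold higher number from compound 1 to compound 2 (1.03 log units; beyond the scatter) was the single measured step and was large. Compound 3 `O=Cc1c(-c2ccc([N+](=O)[O-])cc2)nc2sc(Cc3ccc(Cl)cc3)nn12` is the unmeasured member. The change from compound 2 to compound 3 is nitro in place of hydrogen on an aromatic carbon, para to a large group. The measured step bears on it directly: removing the bromo from that same carbon, an 11-fold higher number from compound 1 to compound 2 (1.03 log units; beyond the scatter), was large and went upward, so restoring a substituent there in compound 3 is expected to move the number back down. Compound 3 is therefore estimated to show the step of a 7.5-fold lower number from compound 2 to compound 3 (0.88 log units; beyond the scatter) in this assay. Compound 3 is expected near 6000 nM, within 2000 nM to 20000 nM.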

Compound 3, half-maximal inhibitory concentration: 17000 nM
The estimate for compound 3 lay 2.8-fold (0.45 log units) below the measured number; measured number inside the range.
By their numbers in this assay, from the lowest: compound 1; then compound 3; then compound 2.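

In this assay, a second substituent on this carbon also lowers the number relative to the unsubstituted phenyl, a 2.6-fold lower number from compound 2 to compound 3 (0.42 log units; beyond the scatter), so among the compounds shown the drop is not confined to bromo. The two substituents are not interchangeable, however: nitro in place of bromo gives a 4.0-fold higher number from compound 1 to compound 3 (0.61 log units; beyond the scatter), which places compound 3 between compound 1 and compound 2 and leaves compound 1 with the lowest number of the three. Nothing measured here accounts for the difference between the two groups.

From the compounds shown here alone, whether an amine, a methoxy group or a carboxylic acid on the same carbon would fall within this range remains open. The compounds shown also share everything outside this one position, so whether the order holds after a change elsewhere in the molecule is unknown.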